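The source may hold more compounds than are shown below. What is called first, only, known or untested is meant among the compounds shown, and "the series" means these compounds.

Compound 1, `C=CCCCCCCCC#CC#CC(O)CC(C)=O`: 3.34 ug/mL
Compound 2, `C=CCCCCCCCC#CC#CCOCC(=O)O`: 4.88 ug/mL

In a functional assay on SK-OV-3 cells (Homo sapiens) for cytotoxicity (on this read-out lower numbers stand for an effect already at smaller amounts and higher numbers for an effect only at larger amounts of compound), compound 1 gives 3.34 ug/mL and compound 2 gives 4.88 ug/mL, so compound 1 holds the lower of the two numbers, though the step of a 1.5-fold higher number from compound 1 to compound 2 (0.16 log units; within the scatter) does not separate them. Compound 3, `CCCCCCCC#CC#CC(O)CC(C)=O`, differs from compound 1 by hydrogen in place of vinyl on a saturated chain carbon, seven bonds along the chain from a triple-bonded carbon. Among the measured compounds shown here, no measured step touches this part of the chain; the single measured step concerns a different position and stays within the scatter. Therefore no change beyond the scatter is expected: a 1.0-fold higher number from compound 1 to compound 3 (0.02 log units; within the scatter). Compound 3 is estimated at 3.5 ug/mL, between 1.5 ug/mL and 8.5 ug/mL.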

Compound 3, concentration for half-maximal effect: 1.81 ug/mL
Beside the measured number, compound 3's estimate is 1.9-fold (0.29 log units) above it, within the range that was stated.
By their numbers in this assay, from the lowest: compounds 3, 1 and 2 (each within the scatter of the next, the first and the last beyond it).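

Replacing vinyl with hydrogen on a saturated chain carbon, seven bonds along the chain from a triple-bonded carbon, gives a 1.8-fold lower number from compound 1 to compound 3 (0.27 log units; within the scatter) in this assay. Cytotoxicity therefore remains when the chain loses the vinyl group and its double bond, and this is the first look at any change in this part of the chain. Nothing available here bears on the reason for this result. Still open, on these data alone, is whether a longer saturated chain, or an amine at this same place, would move the number beyond the scatter.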